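Benzyl exchange from compound 2 to compound 3

This account rests on a few compounds, and the source may have more. Where it says the series, first, only, none or still open, it means among the compounds named here.

Among the compounds with values here, in a functional assay on A-375 cells (Homo sapiens) for antiproliferative activity, read by MTT assay, with a stated time of 24 h (a lower number here means a stronger inhibitor, a higher number a weaker inhibitor), compound 2 (`COc1cc(OC)c(-c2coc3cc(OCc4ccccc4F)ccc3c2=O)cc1OC`) gives 2100 nM, the only true number so far. Compound 1 (`COc1cccc(C(=O)Oc2ccc3c(=O)c(-c4cc(OC)c(OC)cc4OC)coc3c2)c1`) gives > 10000 nM, which is a limit of the assay and not a number. Within the data shown here, the single measured step, an at least 4.7-fold lower number from compound 1 to compound 2 (0.67 log units; beyond the scatter), puts 2-fluorobenzyl in place of (3-methoxyphenyl)carbonyl and lies beyond the scatter.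

Compound 3 (`COc1cc(OC)c(-c2coc3cc(OCc4ccc(Br)cc4)ccc3c2=O)cc1OC`) keeps the core of compound 2 and carries 4-bromophenyl in place of 2-fluorophenyl on a saturated chain carbon bound to an oxygen on an aromatic ring. The measured step exchanged the whole group on the oxygen, whereas this change leaves the benzyl frame in place, so that step bears on it only loosely. Among the measured compounds shown here, no measured pair compares two substituted benzyl groups, and the data give no direction. No step beyond the scatter is therefore expected in this assay, and the expected step is a 1.1-fold lower number from compound 2 to compound 3 (0.02 log units; within the scatter). With compound 2 at 2100 nM as the sole anchor, the range is kept wide. For compound 3 the estimated value is 2000 nM, with an expected range of 700 nM to 6500 nM.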

Compound 3, half-maximal inhibitory concentration: 1000 nM
The estimate for compound 3 lay 2.0-fold (0.30 log units) above the measured number; low and high end bracket the measured number.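

Within the benzyl frame, 4-bromophenyl in place of 2-fluorophenyl on a saturated chain carbon bound to an oxygen on an aromatic ring gives a 2.1-fold lower number from compound 2 to compound 3 (0.32 log units; beyond the scatter) in this assay and so shows that this position responds to the substituent on the benzyl group, not only to an exchange of the whole group on the oxygen. With 4-bromobenzyl in place of (3-methoxyphenyl)carbonyl on the same oxygen, the series shows an at least 10-fold lower number from compound 1 to compound 3 (1.00 log units; beyond the scatter) and a second benzyl compound measured clear of compound 1. Compound 1 is a limit of the assay and not a number, so this step gives only a minimum size: the limit of > 10000 nM in this assay, at which 1 of the 3 values shown sits.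

The exchange from 2-fluorobenzyl to 4-bromobenzyl alters the halogen and its place together, and the compounds shown do not separate these two changes. Also open, on these data alone, is how the unsubstituted benzyl, 2-bromobenzyl and 4-fluorobenzyl groups would compare on this oxygen, and whether a benzyl group carrying an amine or a carboxylic acid would keep the number of compound 3.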